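The source may hold more compounds than are shown below. What is called first, only, known or untested is meant among the compounds shown, and "the series" means these compounds.

Compound 1 `Brc1cccc(Nc2nc(-c3ccncc3)cs2)c1`: 40700 nM
Compound 2 `Fc1cccc(Nc2nc(-c3ccncc3)cs2)c1`: 40700 nM
Compound 3 `Cc1cccc(Nc2nc(-c3ccncc3)c(C)s2)c1`: 10000 nM

In a functional assay on RCC4 cells (Homo sapiens) for inhibition, read by XTT assay, with a stated time of 4 days (on this read-out higher numbers stand for weaker inhibition and lower numbers for stronger inhibition), compound 3 has the lowest number of the three; compound 1 and compound 2 both stand above it, beyond the scatter. Compound 4 `COC(=O)C=CC(=O)c1sc(Nc2cccc(C)c2)nc1-c1ccncc1` differs from compound 3 in one place: (2-(methoxycarbonyl)ethenyl)carbonyl in place of methyl on an aromatic carbon. Going by the values given here, the only one-place step measured so far, no change at the digits printed from compound 1 to compound 2 (within the scatter), exchanges one halogen for another on an aromatic carbon and does not bear on a change at the core; no measured step involves the group that enters here. The direction and size of the step are therefore open. Compound 4 is expected to give 6000 nM in this assay, within 1500 nM to 30000 nM. The estimated step of a 1.7-fold lower number from compound 3 to compound 4 (0.22 log units; within the scatter) is thus modest and uncertain.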

Compound 4, half-maximal inhibitory concentration: 2510 nM
For compound 4 the middle estimate is 2.4-fold (0.38 log units) above the measured one; the range from low to high includes it.
By their numbers in this assay, from the lowest: compound 4; then compound 3; then compounds 1 and 2 (each within the scatter of the next).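

In this assay, exchanging methyl for (2-(methoxycarbonyl)ethenyl)carbonyl on the aromatic carbon next to the ring sulfur gives a 4.0-fold lower number from compound 3 to compound 4 (0.60 log units; beyond the scatter). This position therefore accepts a much larger group than methyl without losing inhibition, and a change here moves the number beyond the scatter. Nothing available explains this shift. The compounds shown leave open which part of the entering group matters. A plain acetyl group, a carboxylic acid in place of the methyl ester, or a saturated chain at this position could help separate those parts.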